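Methoxy in Place of Chloro Across Two Cytotoxicity Pairs

The source may hold more compounds than are shown below. What is called first, only, known or untested is meant among the compounds shown, and "the series" means these compounds.

Compound 2 `N#Cc1c(N)cccc1Sc1cccc(Cl)c1` and compound 1 `COc1cccc(Sc2cccc(N)c2C#N)c1` share a core and differ by methoxy in place of chloro on an aromatic carbon. In a functional assay on MT4 cells (Homo sapiens) for cytotoxicity (on this read-out lower numbers stand for stronger inhibition and higher numbers for weaker inhibition), compound 2 gives 53000 nM. For compound 1 this assay reports only a limit, > 200000 nM. The step comes out as an at least 3.7-fold higher number from compound 2 to compound 1 (0.57 log units; beyond the scatter), and its size is known only as a bound because of the limit of > 200000 nM in this assay, at which 2 of the 3 values shown sit.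

Compound 3 `Cc1cc(Cl)cc(S(=O)(=O)c2cccc(N)c2C#N)c1` has a core whose difference from compound 2 is not broken down here. In this assay compound 3 gives only a limit, > 200000 nM. Compound 4 `COc1cc(C)cc(S(=O)(=O)c2cccc(N)c2C#N)c1` differs from compound 3 by methoxy in place of chloro on an aromatic carbon, the same kind of change as before, here also meta to a methyl group. Since compound 3 already sits at a limit, the step from compound 3 to compound 4 is expected to be a step that the limit leaves unreadable from compound 3 to compound 4, with compound 4 most likely again at a limit. Compound 4 is therefore estimated at 300000 nM, between 120000 nM and 1000000 nM.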

Compound 4, half-maximal inhibitory concentration: 94000 nM
Beside the measured number, compound 4's estimate is 3.2-fold (0.50 log units) above it, and the stated range ends above it.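

Methoxy in place of chloro gives an at least 2.1-fold lower number from compound 3 to compound 4 (0.32 log units; beyond the scatter) in this assay, so the change does not carry over unchanged from one core to the other: the same change on two cores in this assay, an at least 3.7-fold higher number (0.57 log units; beyond the scatter) from compound 2 to compound 1 and an at least 2.1-fold lower number (0.32 log units; beyond the scatter) from compound 3 to compound 4, at least 8.0-fold (0.90 log units) apart, beyond the scatter of two such steps. Each of the two steps is known only as a bound, and its full size remains unread: the limit of > 200000 nM in this assay, at which 2 of the 4 values shown sit. The two pairs show that the core matters to the result of this change, but they do not show which feature of the cores sets its direction, and two pairs make no rule for the series.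

The compounds shown leave open how an amine or a carboxylic acid in place of the chloro would read in this assay. As far as these compounds go, whether a longer chain such as ethoxy would follow methoxy on either core also stays open.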